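Working notes: trifluoromethyl to methoxy in a triazine series

A few compounds are considered here, and "the series" means these few. Any claim that something is new, unique, unknown or untested is made for them only; others in the source may bear on it.

Measured compounds:
compound 1 `Cc1cc(=O)oc2cc(OCc3nc(N)nc(Nc4ccc(O)cc4)n3)ccc12` — "not determined" (no result reported)
compound 2 `Cc1ccc(Nc2nc(N)nc(COc3cccc(N4CCOCC4=O)c3)n2)cc1Cl` — "not determined" (no result reported)
compound 3 `Cc1ccc(Nc2nc(N)nc(COc3cc(N4CCCC4=O)cc(C(F)(F)F)c3)n2)cc1Cl` — 3190 nM

Of the three compounds carrying the shared core, only compound 3 has a number in an assay on COS-7 cells for agonist activity at Free fatty acid receptor 1 (Homo sapiens), read by scintillation counting and inositol phosphate accumulation, with a stated time of 90 min; a higher number here means that more compound is needed for the effect, a lower number that less compound is needed: compound 3 gives 3190 nM. Going by the values given here, for compound 1 and compound 2 no result was reported in this assay, so compound 3 is the only anchor for the series and no comparison between measured compounds can be drawn.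

Compound 4 `COc1cc(OCc2nc(N)nc(Nc3ccc(C)c(Cl)c3)n2)cc(N2CCCC2=O)c1` is the next entry for this assay. Compared with compound 3, the change is methoxy in place of trifluoromethyl on an aromatic carbon — methoxy in place of trifluoromethyl on an aromatic carbon, a position meta to the 2-oxopyrrolidin-1-yl group and meta to a large group on that ring.

Among the compounds with values here, with no step between measured compounds available, the size of this step is not anchored by anything in the set. The expectation is that the step from compound 3 to compound 4 in this assay stays within or close to the usual scatter, with the uncertainty leaning toward compound 4 needing somewhat more compound; this is estimated as a 1.4-fold higher number from compound 3 to compound 4 (0.15 log units; within the scatter). Compound 4 is thus expected to give about 4500 nM, with a range from 1200 nM to 15000 nM.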

Compound 4, half-maximal effective concentration: 1800 nM
Compound 4: the middle estimate sits 2.5-fold (0.40 log units) above what was measured; the range from low to high includes it.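

In this assay, going by these compounds alone, the exchange of trifluoromethyl for methoxy, on the aromatic carbon meta to the 2-oxopyrrolidin-1-yl group, gives a 1.8-fold lower number from compound 3 to compound 4 (0.25 log units; within the scatter), the first step that can be read between two measured compounds. At this position, a group with a hydrogen-bond acceptor and fewer heavy atoms therefore gives a result that cannot be told apart from that of trifluoromethyl, so this single pair shows no measurable dependence on which of the two groups is present. No measurement is at hand that would explain this result.

Going by these compounds, with compound 1 and compound 2 still without a number, the reading rests on this one pair, and it is open whether the same exchange would read alike with another group in place of the 2-oxopyrrolidin-1-yl group. Also open, on these data alone, is whether a hydrogen, a chlorine, an ethoxy group, a primary amine or a carboxylic acid on the same aromatic carbon would stay within the scatter of compound 3 and compound 4 or move clearly away from them.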